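Permeability notes: pyridinyloxy series, PAMPA

The compounds below may be only part of what the source reports. "The series", "measured", "known", "first", "only" and "open" are said of these compounds alone.

Measured compounds:
compound 1 `Cn1c(COc2cccc(C(=O)O)c2)nc2cnc(Oc3ccc4c(c3)OCC4)cc21` — 3.6 10^-6 cm/s
compound 2 `Cn1c(COc2cccc(C(=O)O)c2)nc2ccc(Oc3ccccn3)cc21` — 2.2 10^-6 cm/s

Both numbers come from an ADME assay for permeability, using PAMPA, with a stated time of 4 h; a higher number here means that the compound crosses the layer faster, a lower number that the compound crosses the layer more slowly. In this assay compound 1 gives 3.6 10^-6 cm/s and compound 2 gives 2.2 10^-6 cm/s; the two are within the usual scatter of each other, so the data allow no ranking between them. For the measured compounds named here, compound 2 therefore stands on a pair of numbers that read as one level, and its only point of comparison is compound 1. Going by the values given here, no step between measured compounds that differ in one place is available in this set, so there is no calibrated step to lean on.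

Compound 3 `Cc1ccc(C)c(Oc2ccc3nc(COc4cccc(C(=O)O)c4)n(C)c3c2)n1` is the next member to be measured. It differs from compound 2 in one place: 3,6-dimethylpyridin-2-yl in place of pyridin-2-yl on an oxygen on an aromatic ring. The rest of the molecule, the shared core and the carboxylic acid side, is unchanged.

Among the compounds with values here, with no measured step of comparable kind, the expectation rests on the two numbers alone. The step of a 1.4-fold higher number from compound 2 to compound 3 (0.13 log units; within the scatter) is expected to be small, at most modestly upward and quite possibly not beyond the scatter. For compound 3 the estimate in this assay is 3 10^-6 cm/s, with a range from 1.5 10^-6 cm/s to 6 10^-6 cm/s.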

Compound 3, apparent permeability: 11 10^-6 cm/s
Estimate against measurement, compound 3: 3.7-fold (0.56 log units) below, outside the stated range (above it).
By their numbers in this assay, from the lowest: compounds 2 and 1 (each within the scatter of the next); then compound 3.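

In this assay, for the compounds shown here, the change from pyridin-2-yl to 3,6-dimethylpyridin-2-yl on an oxygen on an aromatic ring gives a 5.0-fold higher number from compound 2 to compound 3 (0.70 log units; beyond the scatter), the first step in this set that can be read at all, and it lies beyond the scatter. This place on the molecule is therefore not silent in this read-out: the number moves with the shared core and the carboxylic acid side unchanged, and with hydrogen-bond donors, hydrogen-bond acceptors and net charge the same on both groups. Nothing measured here bears on why the number moves.

On these data alone, the two methyl groups enter together, so it remains open whether either one alone carries the step, and whether a pyridin-2-yl with a single methyl, ethyl, methoxy or chlorine in their place would give a step of similar size. As far as these compounds go, the step also rests on a single pair, so whether the same change holds on the core of compound 1, or on any other aryl group on that oxygen, remains open.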